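A few compounds are considered here, and "the series" means these few. Any claim that something is new, unique, unknown or untested is made for them only; others in the source may bear on it.

Among the compounds with values here, in a physicochemical assay for solubility, in phosphate buffer, with a stated time of 24 h, at pH 7.4 (on this read-out lower numbers stand for lower solubility and higher numbers for higher solubility), compound 1 `CCOCc1[nH]c(=O)c(-c2nnc(Cc3ccc(Cl)cc3)o2)c(O)c1-c1c(OC)cccc1OC` gives 26 ug/mL and compound 2 `COCCc1[nH]c(=O)c(-c2nnc(Cc3ccc(Cl)cc3)o2)c(O)c1-c1c(OC)cccc1OC` gives 73 ug/mL which is the higher of the two numbers so far. Compound 3 `CCCCc1[nH]c(=O)c(-c2nnc(Cc3ccc(Cl)cc3)o2)c(O)c1-c1c(OC)cccc1OC` differs from compound 2 by ethyl in place of methoxy on a saturated chain carbon, two bonds along the chain from an aromatic carbon with ethyl in place of methoxy on a saturated chain carbon, two bonds along the chain from an aromatic carbon. Within the data shown here, the only measured step that bears on this is the modest 2.8-fold higher number from compound 1 to compound 2 (0.45 log units; beyond the scatter) which swaps ethoxy for methoxymethyl, and no measured compound lacks the chain oxygen. A modest drop in this assay is therefore expected, with an estimated 3.3-fold lower number from compound 2 to compound 3 (0.52 log units; beyond the scatter) beyond the scatter. Compound 3 is expected at 22 ug/mL within an estimated range of 7 ug/mL to 60 ug/mL on this read-out.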

Compound 3, solubility: < 1 ug/mL
Compound 3: no number, only a limit (the forecaster's own chance of this, stated with the estimate: 3%); middle value at least 22-fold (1.34 log units) away from the limit.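

In this assay, ethyl in place of methoxy on a saturated chain carbon, two bonds along the chain from an aromatic carbon, is a large step: an at least 73-fold lower number from compound 2 to compound 3 (1.86 log units; beyond the scatter). Propyl in place of ethoxy is also large, an at least 26-fold lower number from compound 1 to compound 3 (1.41 log units; beyond the scatter), so both oxygen-bearing chains stand well clear of the all-carbon butyl chain, which the earlier pair could not show. Compound 3 gives a limit, not a number: the limit of < 1 ug/mL in this assay, at which 1 of the 3 values shown sits.

On these data alone, the full size of both steps stays open. Also open, as far as these compounds go, is where a hydroxyl, an amine, a carboxylic acid or a longer ether chain at this position would fall relative to compound 2.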